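Phthalonitrile thioethers: from phenethyl to isopentyl

The source may hold more compounds than are shown below. What is called first, only, known or untested is meant among the compounds shown, and "the series" means these compounds.

Measured compounds:
compound 1 `COc1ccc(CSc2ccc(C#N)c(C#N)c2)cc1` — 129000 nM
compound 2 `N#Cc1ccc(SCCc2ccccc2)cc1C#N` — 7190 nM

Both compounds were tested in an assay on microsomes for inhibition of Amine oxidase [flavin-containing] A (Homo sapiens), read by fluorescence and spectrophotometry, with a stated time of 20 min; on this read-out lower numbers stand for stronger inhibition and higher numbers for weaker inhibition. Compound 1 gives 129000 nM and compound 2 gives 7190 nM, so compound 2 holds the lower of the two numbers shown, and the gap to compound 1 lies beyond the usual scatter of this assay. Compound 2 is therefore the reference point for the next step.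

Compound 3 `CC(C)CCSc1ccc(C#N)c(C#N)c1` differs from compound 2 in one place: isopropyl in place of phenyl on a saturated chain carbon, two bonds along the chain from a sulfur. The chain carrying the sulfur is kept; only the terminal group on it changes. Among the compounds with values here, no pair of measured compounds shows this kind of exchange, so there is no measured step to lean on. The two values on hand only show that the terminal group matters in this series. The expectation is that compound 3 gives a weaker result than compound 2, with the step from compound 2 to compound 3 estimated as a 3.1-fold higher number from compound 2 to compound 3 (0.49 log units; beyond the scatter), beyond the scatter but well short of the gap between compound 1 and compound 2. For compound 3 in this assay the estimate is 22000 nM, with a range from 6000 nM to 80000 nM.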

Compound 3, half-maximal inhibitory concentration: 1450 nM
Estimate against measurement, compound 3: 15-fold (1.18 log units) above; the measured number lies below the stated range.
By their numbers in this assay, from the lowest: compound 3; then compound 2; then compound 1.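

In this assay, isopropyl in place of phenyl on a saturated chain carbon, two bonds along the chain from a sulfur, gives a 5.0-fold lower number from compound 2 to compound 3 (0.70 log units; beyond the scatter), a step beyond the scatter, so an aromatic ring at this place is not needed for inhibition in this pair. The change removes the ring and goes from 6 heavy atoms to 3, while the counts of hydrogen-bond donors and acceptors stay at 0 and neither group carries a net charge, so the gain comes with a smaller, ring-free terminal group and no change in those counts. Nothing measured here accounts for the step, and this single pair supports no wider pattern.

Within the data shown here, the single step does not separate the loss of the aromatic ring from the loss of heavy atoms, and a cyclohexyl group on the same chain carbon would bear directly on that. As far as these compounds go, how far the trend extends also stays open, whether to a tert-butyl group, a longer chain, or a terminal amine or carboxylic acid at this place.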